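The source may report more compounds than this note shows. Statements on the series, on what has been measured and on what is new or still open speak of the compounds shown alone.

Measured so far in a functional assay on SiHa cells (Homo sapiens) for cytotoxicity, read by MTT assay, with a stated time of 48 h; a higher number here means a weaker inhibitor, a lower number a stronger inhibitor:
- compound 1, `CCCCCCCCCCCCNC(=O)[C@@H](NC(=O)c1cccs1)[C@@H](C)O`: 23900 nM
- compound 2, `CCCCCCCCCCCCNC(=O)[C@@H](NC(=O)c1cc2ccccc2o1)[C@@H](C)O`: 12900 nM
- compound 3, `CCCCCCCCCCCCCCCCCCNC(=O)[C@@H](NC(=O)c1cccs1)[C@@H](C)O`: 117000 nM

Compound 4, `CCCCCCCCCCCCCCCCCCNC(=O)[C@@H](NC(=O)c1cc2ccccc2o1)[C@@H](C)O`, has not been measured in this assay.

Compound 1 and compound 3 share a core that differs in one counted place: hexyl in place of hydrogen on a saturated chain carbon, ten or more bonds along the chain from an amide-type nitrogen. That difference gave a 4.9-fold higher number from compound 1 to compound 3 (0.69 log units; beyond the scatter). Compound 3 stands with the highest number of the three measured compounds.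

The change from compound 3 to compound 4 is 1-benzofuran-2-yl in place of thiophen-2-yl on a carbonyl carbon. The same change is already measured once, between compound 1 and compound 2: 1-benzofuran-2-yl in place of thiophen-2-yl on a carbonyl carbon. There it gave a 1.9-fold lower number from compound 1 to compound 2 (0.27 log units; within the scatter). The place of the change reads the same in both pairs, so the two changes are the same change on two different cores, and the change occurs twice among the compounds shown.

Among the compounds with values here, for compound 4 the step is expected to be a 1.7-fold lower number from compound 3 to compound 4 (0.22 log units; within the scatter), resting on the earlier step of a 1.9-fold lower number from compound 1 to compound 2 (0.27 log units; within the scatter), with the wider range because only one instance of the change is measured. Compound 4 is thus expected to give about 70000 nM in this assay, estimated between 35000 nM and 160000 nM.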

Compound 4, half-maximal inhibitory concentration: > 200000 nM
Compound 4 gave a limit, no number (the forecaster's own chance of this, stated with the estimate: 15%); middle value at least 2.8-fold (0.45 log units) away from the limit.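

In this assay compound 4 gives > 200000 nM, which is a limit of the assay and not a number. Placing 1-benzofuran-2-yl instead of thiophen-2-yl on the carbonyl carbon gives an at least 1.7-fold higher number from compound 3 to compound 4 (0.23 log units; that floor lies within the scatter), so the step measured on the core of compound 1 does not carry over to the core of compound 3 with its size intact: the same change on two cores in this assay, a 1.9-fold lower number (0.27 log units; within the scatter) from compound 1 to compound 2 and an at least 1.7-fold higher number (0.23 log units; that floor lies within the scatter) from compound 3 to compound 4, at least 3.1-fold (0.50 log units) apart, beyond the scatter of two such steps. Placing hexyl on the saturated chain gives an at least 15-fold higher number from compound 2 to compound 4 (1.19 log units; beyond the scatter), which shares its direction with the step on the thiophen-2-yl core but not its size, while both new steps remain floors, so their true sizes are not read and two cores fix no rule for the series: the same change on two cores in this assay, a 4.9-fold higher number (0.69 log units; beyond the scatter) from compound 1 to compound 3 and an at least 15-fold higher number (1.19 log units; beyond the scatter) from compound 2 to compound 4, at least 3.1-fold (0.50 log units) apart, beyond the scatter of two such steps.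

Whether the two changes depend on each other over a wider range of chains stays open, since only two chain lengths and two groups on the carbonyl carbon are shown. A shorter chain, or a phenyl or furan-2-yl group on the carbonyl carbon, would give steps that could be read as numbers.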